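The source may hold more compounds than are shown below. What is called first, only, known or untested is meant among the compounds shown, and "the series" means these compounds.

Compound 1 (`COc1cc(C(=O)n2ccc3ccccc32)cc(OC)c1OC`): 8400 nM
Compound 2 (`COc1cc(C(=O)c2cccc3c2ccn3C)cc(OC)c1OC`): 26.9 nM
Compound 3 (`CCn1ccc2cc(C(=O)c3cc(OC)c(OC)c(OC)c3)ccc21`): 41 nM

In a functional assay on TSGH cells (Homo sapiens) for inhibition, with a stated time of 72 h (on this read-out lower numbers stand for stronger inhibition and higher numbers for weaker inhibition), compound 3 (41 nM) lies within the scatter of compound 2 (26.9 nM) and far below compound 1 (8400 nM). Compound 4 (`COc1cc(C(=O)c2ccc3c(ccn3CCN(C)C)c2)cc(OC)c1OC`) is compound 3 with one change, ethyl to 2-(dimethylamino)ethyl (dimethylamino in place of hydrogen on a saturated chain carbon, two bonds along the chain from an aromatic nitrogen). Going by the values given here, no measured pair tests this change, so the expectation is loose: a moderate step towards higher numbers in this assay, probably somewhat beyond the scatter. The expected shift is estimated as a 2.9-fold higher number from compound 3 to compound 4 (0.47 log units; beyond the scatter) and remains uncertain in size. Compound 4 is estimated at 120 nM (expected range 35 nM to 500 nM).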

Compound 4, half-maximal inhibitory concentration: 4900 nM
Beside the measured number, compound 4's estimate is 41-fold (1.61 log units) below it, and the stated range ends below it.
By their numbers in this assay, from the lowest: compounds 2 and 3 (each within the scatter of the next); then compounds 4 and 1 (each within the scatter of the next).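

In this assay, replacing ethyl with 2-(dimethylamino)ethyl gives a 120-fold higher number from compound 3 to compound 4 (2.08 log units; beyond the scatter) and so a large loss of inhibition. Going by these compounds alone, the saturated chain on the aromatic nitrogen of compound 3 therefore does not accept the dimethylamino group, a limit that the earlier compounds did not show. Nothing at hand accounts for the size of this step. Still open, on these data alone, is whether the loss follows the amine itself or the longer chain. A propyl or 2-methoxyethyl chain, or a morpholine in place of dimethylamino, would help separate these readings.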